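A few compounds are considered here, and "the series" means these few. Any claim that something is new, unique, unknown or untested is made for them only; others in the source may bear on it.

Compound 1: `CCS(=O)(=O)Nc1cc(-c2ccc3ncnc(Nc4ccc(OC)c(Cl)c4)c3c2)cnc1OC` — 5240 nM
Compound 2: `CCS(=O)(=O)Nc1cc(-c2ccc3ncnc(Nc4ccc(C(=O)OC)c(OC)c4)c3c2)cnc1OC` — 3350 nM

Both compounds share one core and differ only in the aryl group on the nitrogen on the aromatic ring. In a functional assay on A549 cells (Homo sapiens) for cytotoxicity, read by sulforhodamine B assay, with a stated time of 72 h (a higher number here means a weaker inhibitor, a lower number a stronger inhibitor), compound 1 gives 5240 nM, and compound 2 gives 3350 nM. The step of a 1.6-fold lower number from compound 1 to compound 2 (0.19 log units; within the scatter) is the only measured one, and it lies within the scatter, so the two compounds cannot be ordered; compound 2 has the lowest of the two numbers, with compound 1 as its nearest neighbour.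

Compound 3 is `CCS(=O)(=O)Nc1cc(-c2ccc3ncnc(Nc4ccc(F)nc4)c3c2)cnc1OC`. Its change from compound 2 is 6-fluoropyridin-3-yl in place of 3-methoxy-4-(methoxycarbonyl)phenyl on a nitrogen on an aromatic ring. Within the data shown here, no measured step concerns this particular swap, and the one step available, a 1.6-fold lower number from compound 1 to compound 2 (0.19 log units; within the scatter), concerned a different pair of aryl groups and was itself within the scatter. The data therefore give no ground for expecting a shift beyond the scatter in this assay in either direction, though the replacement is larger in kind than the one measured, so the uncertainty is wide. Compound 3 is estimated at 4000 nM, within a range of 1000 nM to 16000 nM, which corresponds to an expected step of a 1.2-fold higher number from compound 2 to compound 3 (0.08 log units; within the scatter).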

Compound 3, half-maximal inhibitory concentration: 6720 nM
Compound 3: the middle estimate sits 1.7-fold (0.23 log units) below what was measured, within the range that was stated.
By their numbers in this assay, from the lowest: compounds 2, 1 and 3 (each within the scatter of the next).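

In this assay, the step of a 2.0-fold higher number from compound 2 to compound 3 (0.30 log units; within the scatter) replaces 3-methoxy-4-(methoxycarbonyl)phenyl, with 12 heavy atoms and a ring of carbon only, by 6-fluoropyridin-3-yl, with 7 heavy atoms and a ring holding one hetero atom. The comparison with the third aryl group, 3-chloro-4-methoxyphenyl, gives a 1.3-fold higher number from compound 1 to compound 3 (0.11 log units; within the scatter) and so also stays unresolved. Where the first pair showed only that two substituted phenyl groups could not be told apart, these steps extend this to a change of ring type and a loss of 5 heavy atoms at the position on a nitrogen on an aromatic ring, and the three aryl groups still cannot be ordered.

The compounds shown leave open whether any group at this position would move the number beyond the scatter, for instance an aryl group carrying an amine or a carboxylic acid, or a simple unsubstituted phenyl, and they say nothing about changes elsewhere on the shared core. No measurement is available here that would help to interpret these numbers.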